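The source may report more compounds than this note shows. Statements on the series, on what has been measured and on what is new or still open speak of the compounds shown alone.

Measured in a functional assay on PANC-1 cells (Homo sapiens) for antiproliferative activity, read by WST assay, with a stated time of 96 h; a higher number here means a weaker inhibitor, a lower number a stronger inhibitor:
compound 1 `CCC[C@H]1C[C@@H](OC)C/C(C)=C\[C@@H]2C[C@@H](OC(=O)CCCCc3coc(CCCNC(=O)OC)n3)C[C@H](CC(=O)O1)O2`: 3200 nM
compound 2 `CCC[C@H]1C[C@@H](OC)C/C(C)=C\[C@@H]2C[C@@H](OC(=O)/C=C\CCc3coc(/C=C\CNC(=O)OC)n3)C[C@H](CC(=O)O1)O2`: 2.4 nM

Compound 1 has the higher number of the two, making it the weaker inhibitor, and the gap to compound 2 is beyond the scatter. Compound 3 `CCC[C@H]1C[C@@H](OC)C/C(C)=C\[C@@H]2C[C@@H](OC(=O)CCCCc3coc(/C=C\CNC(=O)OC)n3)C[C@H](CC(=O)O1)O2` has 3-((methoxycarbonyl)amino)prop-1-en-1-yl in place of 3-((methoxycarbonyl)amino)propyl on an aromatic carbon of compound 1 (3-((methoxycarbonyl)amino)prop-1-en-1-yl in place of 3-((methoxycarbonyl)amino)propyl on an aromatic carbon). Compound 2, at 2.4 nM, carries the same new group but also differs from compound 1 elsewhere, so only part of that gap is expected here. The expected change in this assay is a large one toward a lower number, a 32-fold lower number from compound 1 to compound 3 (1.51 log units; beyond the scatter). For compound 3 the estimated value is 100 nM, within an expected range of 8 nM to 1500 nM.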

Compound 3, half-maximal inhibitory concentration: 26 nM
Estimate against measurement, compound 3: 3.8-fold (0.59 log units) above; the range from low to high includes it.
By their numbers in this assay, from the lowest: compound 2; then compound 3; then compound 1.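

In this assay, putting 3-((methoxycarbonyl)amino)prop-1-en-1-yl in place of 3-((methoxycarbonyl)amino)propyl gives a 120-fold lower number from compound 1 to compound 3 (2.09 log units; beyond the scatter) and so shows that this single change is enough for a large gain in potency. The two groups share the same heavy atoms and differ by one double bond, so a small edit to the chain at this position matters greatly. Nothing measured here explains the size of this step. Still open, on these data alone, is how a longer chain or a triple bond in the same place would compare.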